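The source may report more compounds than this note shows. Statements on the series, on what has been measured and on what is new or still open speak of the compounds shown alone.

Measured so far:
Compound 1, `CCc1ccccc1-c1nc(N)nc(N)n1`, gives 1.65 in a physicochemical assay for lipophilicity; on this read-out higher numbers stand for higher lipophilicity and lower numbers for lower lipophilicity.
Compound 2, `Nc1nc(N)nc(-c2cc(F)ccc2Cl)n1`, gives 1.38 in this assay.

Compound 1 has the higher of the two numbers, but its nearest neighbour, compound 2, sits only a little lower, and that gap lies within the usual scatter of this kind of measurement, so the two cannot be told apart on these numbers alone.

The unmeasured compound 3, `COc1ccccc1-c1nc(N)nc(N)n1`, keeps the shared core of compound 1 and changes one group on the aromatic ring: methoxy in place of ethyl on an aromatic carbon. Among the compounds with values here, no measured pair here differs by just such a swap, so there is no directly observed step to lean on. Still, the exchange removes a two-carbon chain and brings in an oxygen that counts as a hydrogen-bond acceptor, and in this assay such an exchange is expected to give a clear downward step, well beyond the scatter.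

Starting from compound 1, whose value is 1.65, compound 3 is expected to come out at 0.7, with a likely range from 0.3 to 1.1, an expected step of a number 0.95 log units lower from compound 1 to compound 3 (beyond the scatter).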

Compound 3, partition coefficient: 0.58
For compound 3 the middle estimate is 0.12 log units above the measured one, within the range that was stated.
By their numbers in this assay, from the lowest: compound 3; then compounds 2 and 1 (each within the scatter of the next).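

At this aromatic carbon, ortho to a group of 8 heavy atoms, placing methoxy in place of ethyl gives in this assay a step that reads a number 1.07 log units lower from compound 1 to compound 3 (beyond the scatter) and is the first step shown here between two compounds that differ in one place. Ethyl and methoxy both count 2 heavy atoms and neither carries a net charge, so this large step comes with a change that leaves the heavy-atom count the same, swapping 1 carbon for 1 oxygen and adding 1 hydrogen-bond acceptor. No measurement shown here explains why the step has this size.

A single pair cannot separate the effect of the oxygen from that of the rest of the methoxy group, and a hydroxyl, an amine or an ethoxy group on the same aromatic carbon would help to tell these apart. From the compounds shown here alone, it also remains open whether methoxy in place of ethyl would give a step of similar size on a different carbon of the ring or on a different core.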